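A few compounds are considered here, and "the series" means these few. Any claim that something is new, unique, unknown or untested is made for them only; others in the source may bear on it.

Among the measured compounds shown here, in a functional assay on Jurkat cells (Homo sapiens) (on this read-out higher numbers stand for weaker inhibition and lower numbers for stronger inhibition), two compounds sharing one core have numbers so far. Compound 1 `C[C@H](NC(=O)C(=O)NCC1(c2ccccc2)CC1)C(=O)N[C@@H](CC(=O)O)C(=O)COc1c(F)c(F)cc(F)c1F` gives 27 nM. Compound 2 `C[C@H](NC(=O)C(=O)NCc1cccc(Cl)c1Cl)C(=O)N[C@@H](CC(=O)O)C(=O)COc1c(F)c(F)cc(F)c1F` gives 76 nM, the higher of the two numbers and so the weaker inhibition. Compound 3 `C[C@H](NC(=O)C(=O)NCc1ccc(Cl)cc1Cl)C(=O)N[C@@H](CC(=O)O)C(=O)COc1c(F)c(F)cc(F)c1F` keeps the core of compound 2 and alters only its dichlorophenyl group, with 2,4-dichlorophenyl in place of 2,3-dichlorophenyl on a saturated chain carbon bound to an amide-type nitrogen. The two compounds have the same atoms, joined differently. For the measured compounds named here, only one measured step bears on this change, at the same place on the molecule: a 2.8-fold higher number from compound 1 to compound 2 (0.45 log units; beyond the scatter), a modest step beyond the scatter. Going by the values given here, that step replaced a whole group, whereas here the group stays a dichlorophenyl, and no measured pair tests a change of this kind. The modest size of the larger replacement therefore suggests no step beyond the scatter in this assay. The expected outcome is a 1.1-fold lower number from compound 2 to compound 3 (0.04 log units; within the scatter). For compound 3 the estimated value is 70 nM, with an expected range of 30 nM to 160 nM.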

Compound 3, half-maximal inhibitory concentration: 165 nM
Compound 3: the middle estimate sits 2.4-fold (0.37 log units) below what was measured; the whole stated range lies below it.
By their numbers in this assay, from the lowest: compound 1; then compound 2; then compound 3.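

In this assay the exchange of 2,3-dichlorophenyl for 2,4-dichlorophenyl on a saturated chain carbon bound to an amide-type nitrogen gives a 2.2-fold higher number from compound 2 to compound 3 (0.34 log units; beyond the scatter) and so shows that this place responds to how the two chlorines are arranged on the ring, even with the atoms unchanged. The earlier compounds had shown only the replacement of a whole group, and this rearrangement is also a modest step, so the group need not change in kind for the number to move beyond the scatter. The replacement of 1-phenylcyclopropyl by 2,4-dichlorophenyl gives a 6.1-fold higher number from compound 1 to compound 3 (0.79 log units; beyond the scatter) and leaves compound 1 as the strongest inhibitor of the three, with compound 3 the weakest, although nothing shown gives a reason for the difference between the two dichlorophenyl groups.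

The compounds shown leave open how a fluorophenyl or methoxyphenyl group, or an unsubstituted phenyl on the same chain carbon, would compare with the two dichlorophenyl groups. They also leave open whether a chlorine on the phenyl of the 1-phenylcyclopropyl group would carry the same dependence on its arrangement.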